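A few compounds are considered here, and "the series" means these few. Any claim that something is new, unique, unknown or untested is made for them only; others in the source may bear on it.

Compound 2 `Cc1cccc2c1CCN2CCNC(=O)Nc1ccccc1Br` gives 7.4 in a functional assay for antagonist activity at transient receptor potential cation channel subfamily V member 1 (Rattus norvegicus), read by FLIPR (a lower number here means a less potent compound, a higher number a more potent compound, by a factor of ten per unit of this negative logarithm), the second highest of three numbers. Compound 1 `O=C(Nc1ccccc1Br)N[C@@H]1CCN(c2ccc(Br)cn2)C1` gives 7.2, within the scatter of compound 2, while compound 3 `Cc1ccc(N2CC[C@@H](NC(=O)Nc3ccccc3Br)C2)cc1F` gives 8.3, beyond it. For the measured compounds named here, the only single-point step measured, a number 1.10 log units higher from compound 1 to compound 3 (beyond the scatter), concerns the aryl group on the ring amine, not the fused ring. Compound 4 `O=C(NCCN1CCc2c(F)cccc21)Nc1ccccc1Br` differs from compound 2 by fluoro in place of methyl on an aromatic carbon. Going by the values given here, no measured pair shows this exchange, so there is no direct precedent to build on. Compound 4 is therefore expected to sit close to compound 2, with a step of a number 0.10 log units lower from compound 2 to compound 4 (within the scatter) that stays within the scatter. The estimate for compound 4 is 7.3, with a range from 6.7 to 7.9.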

Compound 4, negative logarithm of the antagonist equilibrium constant: 7.4
For compound 4 the middle estimate is 0.10 log units below the measured one; the range from low to high includes it.
By their numbers in this assay, from the lowest: compounds 1, 2 and 4 (each within the scatter of the next); then compound 3.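

In this assay, fluoro in place of methyl on this aromatic carbon, ortho to a fused ring and meta to a fused ring, brings no change at the digits printed from compound 2 to compound 4 (within the scatter). For the compounds shown here, this is the first reading at this position, since the earlier step concerned only the aryl group on the ring amine, and it shows that the two groups can be exchanged here with the number held. Nothing available accounts for this result. Open still is how a methoxy group, a chlorine atom or an amine on this carbon would read, and whether plain hydrogen there would hold the number.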